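The source may report more compounds than this note shows. Statements on the series, on what has been measured and on what is new or still open speak of the compounds shown alone.

In a functional assay on A549 cells (Homo sapiens) for inhibition, read by colorimetric assay and MTT assay, with a stated time of 72 h (on this read-out higher numbers stand for weaker inhibition and lower numbers for stronger inhibition), compound 3 `C=CCCOc1ncc(-c2ccccc2OC)n1C` gives 22000 nM, level with compound 2 `C#CCCCCOc1ncc(-c2ccccc2OC)n1C`, which gives 22000 nM, the two together the lowest of three numbers; compound 1 `CCCCCCOc1ncc(-c2ccccc2OC)n1C` gives 37000 nM and is the furthest of the three. The move to compound 4 `COc1ccccc1-c1cnc(OCCCc2ccccc2)n1C` brings (benzyl in place of vinyl on a saturated chain carbon, two bonds along the chain from an oxygen on an aromatic ring). Two measured steps alter the chain at the same place: a 1.7-fold lower number from compound 1 to compound 3 (0.23 log units; within the scatter) and no change at the digits printed from compound 2 to compound 3 (within the scatter). Among the compounds with values here, neither of these brings in an aromatic ring, so the benzyl itself has no precedent here. Since chain changes at this place have stayed within the scatter, the expected step is a 1.1-fold lower number from compound 3 to compound 4 (0.04 log units; within the scatter), nothing beyond the scatter. Compound 4 is therefore estimated at 20000 nM, with a range from 7000 nM to 60000 nM.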

Compound 4, half-maximal inhibitory concentration: 3000 nM
The estimate for compound 4 lay 6.7-fold (0.82 log units) above the measured number; the whole stated range lies above it.
By their numbers in this assay, from the lowest: compound 4; then compounds 2, 3 and 1 (each within the scatter of the next).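

Among these compounds, only the one carrying an aromatic ring on this chain moves beyond the scatter: in this assay the change gives a 7.3-fold lower number from compound 3 to compound 4 (0.87 log units; beyond the scatter) and a 7.3-fold lower number from compound 2 to compound 4 (0.87 log units; beyond the scatter) and also a 12-fold lower number from compound 1 to compound 4 (1.09 log units; beyond the scatter) while the non-aromatic chains stayed within the scatter of one another. This place therefore does respond to what the chain carries, and compound 4 stands as the strongest of the four. As far as these compounds go, it remains open whether the aromatic ring itself matters, and whether a cyclohexyl ring, a pyridine ring or an amine at the chain end would keep the gain. Nothing at hand explains the gain.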